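Series notes: saturated ring in place of pyrazin-2-yl

The compounds below may be only part of what the source reports. "The series", "measured", "known", "first", "only" and "open" are said of these compounds alone.

Measured compounds:
compound 1 `COc1ccc(OC)c(Sc2ccc3nnc(-c4ccccc4)n3n2)c1`, 173 nM
compound 2 `COc1ccc(OC)c(Sc2ccc3nnc(-c4ccncc4)n3n2)c1`, 349 nM
compound 3 `COc1ccc(OC)c(Sc2ccc3nnc(-c4cnccn4)n3n2)c1`, 880 nM

In an assay on isolated protein for inhibition of Leucine-rich repeat serine/threonine-protein kinase 2 (Homo sapiens), in the presence of a further agent that is not named here (on this read-out lower numbers stand for stronger inhibition and higher numbers for weaker inhibition), compound 3 gives the highest number of the three, with compound 2 nearest and compound 1 furthest. Compound 4 `COc1ccc(OC)c(Sc2ccc3nnc(C4CCN(C)C4)n3n2)c1` differs from compound 3 by 1-methylpyrrolidin-3-yl in place of pyrazin-2-yl on an aromatic carbon. The measured steps of a 2.0-fold higher number from compound 1 to compound 2 (0.30 log units; within the scatter), a 5.1-fold higher number from compound 1 to compound 3 (0.71 log units; beyond the scatter) and a 2.5-fold higher number from compound 2 to compound 3 (0.40 log units; beyond the scatter) all exchange one aromatic ring for another, so none bears directly on a change to a non-aromatic ring; they only show that the numbers rise as the aromatic ring is varied. The direction for compound 4 is therefore open, and a wide range is assumed. Compound 4 is expected near 1500 nM, within 350 nM to 6500 nM, an estimated step of a 1.7-fold higher number from compound 3 to compound 4 (0.23 log units; within the scatter).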

Compound 4, half-maximal inhibitory concentration: 12600 nM
Estimate against measurement, compound 4: 8.4-fold (0.92 log units) below; the measured number lies above the stated range.
By their numbers in this assay, from the lowest: compounds 1 and 2 (each within the scatter of the next); then compound 3; then compound 4.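

In this assay, 1-methylpyrrolidin-3-yl on this aromatic carbon gives much larger steps than any exchange of one aromatic ring for another: a 14-fold higher number from compound 3 to compound 4 (1.16 log units; beyond the scatter) and a 36-fold higher number from compound 2 to compound 4 (1.56 log units; beyond the scatter) and a 73-fold higher number from compound 1 to compound 4 (1.86 log units; beyond the scatter). The widest aromatic exchange is only a 5.1-fold higher number from compound 1 to compound 3 (0.71 log units; beyond the scatter), so this position separates these aromatic rings far less than it separates them from this saturated ring. Nothing measured here accounts for the loss.

On these data alone, whether the loss follows the saturated ring itself or its methyl-bearing ring nitrogen remains open. A cyclopentyl group, with no ring nitrogen, would separate the two.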